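Hydroxy in place of hydrogen: a parallel step on two cores

The source may hold more compounds than are shown below. What is called first, only, known or untested is meant among the compounds shown, and "the series" means these compounds.

Compound 1 `COc1ccc(CS(=O)(=O)/C=C/c2cc(OC)c(OC)c(OC)c2)cc1` is the reference of the first pair. In a functional assay on H157 cells (Homo sapiens) for antiproliferative activity, read by trypan blue exclusion (on this read-out lower numbers stand for stronger inhibition and higher numbers for weaker inhibition), compound 1 gives only a limit, > 20000 nM. Compound 2 `COc1ccc(CS(=O)(=O)/C=C/c2c(OC)cc(O)cc2OC)cc1` carries a second core; how its core differs from that of compound 1 is not broken down here. In this assay compound 2 likewise gives only a limit, > 20000 nM.

Compound 3 `COc1ccc(CS(=O)(=O)/C=C/c2cc(OC)c(OC)c(OC)c2)cc1O` is the measured partner of compound 1; the change between them is hydroxy in place of hydrogen on an aromatic carbon. In this assay compound 3 gives 10000 nM. The step of an at least 2.0-fold lower number from compound 1 to compound 3 (0.30 log units; that floor lies within the scatter) is only a floor, because the limit of > 20000 nM in this assay, at which 2 of the 3 values shown sit, sets the starting point of that step as a limit rather than a number.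

Compound 4 `COc1ccc(CS(=O)(=O)/C=C/c2c(OC)cc(O)cc2OC)cc1O` is the unmeasured partner of compound 2, and the change between them is hydroxy in place of hydrogen on an aromatic carbon; the surroundings of the place are the same as in the first pair, so this is the same change on the second core. The expected step is an at least 1.3-fold lower number from compound 2 to compound 4 (0.12 log units; that floor lies within the scatter), and this expectation rests on compound 1 and the step of an at least 2.0-fold lower number from compound 1 to compound 3 (0.30 log units; that floor lies within the scatter), with the reservation that the starting value of compound 2 is a limit, so the result may itself be reported only as a limit. Compound 4 is expected to give about 15000 nM in this assay, with a range from 5000 nM to 40000 nM.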

Compound 4, half-maximal inhibitory concentration: 500 nM
Compound 4: the middle estimate sits 30-fold (1.48 log units) above what was measured; measured number outside the range, below it.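

In this assay the new step, an at least 40-fold lower number from compound 2 to compound 4 (1.60 log units; beyond the scatter), is large and lies beyond the scatter, so on the core of compound 2 hydroxy in place of hydrogen on an aromatic carbon goes with clearly stronger inhibition. On the core of compound 1 the floor of the step stays within the scatter, so the series shows that the change can pay off strongly on one core, but not that its size carries over from one core to the other: the same change on two cores in this assay, an at least 2.0-fold lower number (0.30 log units; that floor lies within the scatter) from compound 1 to compound 3 and an at least 40-fold lower number (1.60 log units; beyond the scatter) from compound 2 to compound 4; the limit leaves it open whether they differ. On these data alone, neither step is a full number, and two pairs support no general rule for the series, so the true size of either step stays unknown: the limit of > 20000 nM in this assay, at which 2 of the 4 values shown sit.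

The compounds shown leave open whether the hydroxy itself is needed on this aromatic carbon, or whether an amine, a fluorine atom or a carboxylic acid in the same place would serve as well. They also leave open whether the large step on the core of compound 2 survives when the neighbouring methoxy group is exchanged for a longer chain such as ethoxy.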